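Catechol nitro chalcones: a thiophene in place of a furan

The source may hold more compounds than are shown below. What is called first, only, known or untested is meant among the compounds shown, and "the series" means these compounds.

Compound 1, with the structure `O=C(/C=C/c1ccoc1)c1cc(O)c(O)c([N+](=O)[O-])c1`, was tested in an assay on isolated protein for inhibition of Amine oxidase [flavin-containing] B (Homo sapiens), read by fluorescence (a higher number here means a weaker inhibitor, a lower number a stronger inhibitor), where compound 1 gives 71400 nM. Two companions share its core and its chain. Compound 2 `N#Cc1ccc(/C=C/C(=O)c2cc(O)c(O)c([N+](=O)[O-])c2)cc1` gives 56600 nM in this assay, and compound 3 `N#Cc1cccc(/C=C/C(=O)c2cc(O)c(O)c([N+](=O)[O-])c2)c1` gives 60600 nM. Compound 1 holds the highest of the three numbers, but its gaps to compound 3 and to compound 2 both lie within the usual scatter of this assay, so the three stand together rather than in any order.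

The account now moves to compound 4 `O=C(/C=C/c1cccs1)c1cc(O)c(O)c([N+](=O)[O-])c1`, which has not yet been measured. It differs from compound 1 in one place: thiophen-2-yl in place of furan-3-yl on a double-bonded chain carbon bound to a double-bonded chain carbon. Nothing measured here speaks to a swap of this kind, so the expectation rests on the closeness of the three known values. The step of a 1.2-fold lower number from compound 1 to compound 4 (0.08 log units; within the scatter) is expected to be none beyond the scatter. Compound 4 is therefore estimated to give about 60000 nM in this assay, with a range from 25000 nM to 150000 nM.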

Compound 4, half-maximal inhibitory concentration: 62900 nM
For compound 4 the middle estimate is 1.0-fold (0.02 log units) below the measured one; low and high end bracket the measured number.
By their numbers in this assay, from the lowest: compounds 2, 3, 4 and 1 (each within the scatter of the next).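

In this assay, thiophen-2-yl in place of furan-3-yl on a double-bonded chain carbon bound to a double-bonded chain carbon gives a 1.1-fold lower number from compound 1 to compound 4 (0.06 log units; within the scatter), so compound 1 and compound 4 stand together. This is the only step shown that differs in one place, and it gives a direct reading at this position: a five-membered aromatic ring with oxygen and one with sulfur cannot be told apart here. No available evidence bears on this result.

The step alters the hetero atom and the point of attachment at once, so the compounds shown leave open what each does alone, which a furan-2-yl or thiophen-3-yl group at this place could separate. They also leave open whether an amine or a carboxylic acid on this ring would stand apart from these values.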